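Aryl change on the shared core, at the assay limit

This account rests on a few compounds, and the source may have more. Where it says the series, first, only, none or still open, it means among the compounds named here.

Measured in a functional assay (plasma) for inhibition, with Oryctolagus cuniculus as the target (a higher number here means that more compound is needed for the effect, a lower number that less compound is needed), so far:
compound 1 `CCOC(=O)c1c(C)cc2cnn(-c3ccc(F)cc3)c(=O)c2c1C` gives >= 50 uM
compound 2 `CCOC(=O)c1c(C)cc2cnn(-c3cccc(OC)c3)c(=O)c2c1C` gives >= 50 uM

Compound 2 stands at >= 50 uM as a limit of this assay and not a number. Compound 1 reads >= 50 uM and that too is a limit. Going by the values given here, the series so far offers only the limit of >= 50 uM in this assay, at which 2 of the 2 values shown sit, and no readable value.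

The next change sits on an aromatic nitrogen of the shared core. Compound 3 `CCOC(=O)c1c(C)cc2cnn(-c3ccc(C)c(Cl)c3)c(=O)c2c1C` carries 3-chloro-4-methylphenyl in place of 3-methoxyphenyl on an aromatic nitrogen and nothing else differs.

Among the compounds with values here, one measured step bears on this, a change of the same group on the same nitrogen, and it is a step that the two limits leave unreadable from compound 1 to compound 2 with no size to carry over. Neither 4-fluorophenyl nor 3-methoxyphenyl has given a number, so no direction can be drawn from them, and compound 3 is expected to stay close to the limit as well. For compound 3 the estimated value is 60 uM with an expected range from 20 uM to 150 uM in this assay as measured. The expected step is a step that the limit leaves unreadable from compound 2 to compound 3 and no clear shift is anticipated.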

Compound 3, concentration for half-maximal effect: >= 50 uM
Compound 3 gave a limit, no number (the forecaster's own chance of this, stated with the estimate: 70%); the middle value is on the limit's open side.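

No step among compound 1, compound 2 and compound 3 can be read, as each gives a limit and not a number: the limit of >= 50 uM in this assay, at which 3 of the 3 values shown sit.

The compounds shown leave open how far each of these aryl groups on the aromatic nitrogen lies from that limit, and whether any aryl group there on the shared core gives a readable value in this assay.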